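The source may hold more compounds than are shown below. What is called first, only, known or untested is meant among the compounds shown, and "the series" means these compounds.

Measured compounds in a functional assay on CCRF-CEM cells (Homo sapiens) for cytotoxicity, read by sulforhodamine B assay, with a stated time of 72 h; on this read-out lower numbers stand for stronger inhibition and higher numbers for weaker inhibition:
compound 1 `OCC#CCSc1cnc2ccccc2c1Cl` gives 4.1 ug/mL;
compound 2 `OCC#CCSc1cnc2ccccc2c1[Se]CC#CCBr` gives 0.2 ug/mL;
compound 3 `OCC#CCSc1cnc2ccccc2c1[Se]CC#CCO` gives 1.4 ug/mL.

Compound 3 stands second highest of the three numbers: its nearest neighbour is compound 1, separated by a 2.9-fold lower number from compound 1 to compound 3 (0.47 log units; beyond the scatter), and its furthest is compound 2, separated by a 7.0-fold higher number from compound 2 to compound 3 (0.85 log units; beyond the scatter). The next compound, compound 4 `C#CC[Se]c1c(SCC#CCO)cnc2ccccc12`, has not yet been measured. It differs from compound 3 in one place: hydrogen in place of hydroxymethyl on a triple-bonded carbon. Cut one bond further out, the same change reads 4-hydroxybut-2-yn-1-yl to propargyl.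

Going by the values given here, no measured step removes a hydroxymethyl, so none bears on this change directly. The closest guide is the step from compound 2 to compound 3, where hydroxy in place of bromo on a saturated chain carbon bound to a triple-bonded carbon gave a 7.0-fold higher number from compound 2 to compound 3 (0.85 log units; beyond the scatter), showing that the end of that chain matters to the read-out. Whether losing the hydroxymethyl helps or hurts cannot be read from three compounds. Because the hydroxy-bearing compound 3 gave 1.4 ug/mL while compound 2 gave 0.2 ug/mL, the expectation leans slightly toward a lower number for compound 4, with wide bounds. Compound 4 is therefore estimated at 1 ug/mL, ranging from 0.35 ug/mL to 3 ug/mL, an expected step of a 1.4-fold lower number from compound 3 to compound 4 (0.15 log units; within the scatter).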

Compound 4, concentration for 50% inhibition: 1.9 ug/mL
The estimate for compound 4 lay 1.9-fold (0.28 log units) below the measured number, and the stated range covers the measured number.
By their numbers in this assay, from the lowest: compound 2; then compounds 3 and 4 (each within the scatter of the next); then compound 1.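

In this assay, hydrogen in place of hydroxymethyl on a triple-bonded carbon gives a 1.4-fold higher number from compound 3 to compound 4 (0.13 log units; within the scatter) and, as this lies within the scatter, the two ends of the chain cannot be told apart here. The bromomethyl end does stand apart, with hydrogen in its place giving a 9.5-fold higher number from compound 2 to compound 4 (0.98 log units; beyond the scatter) and so a step beyond the scatter, while the propargyl group in place of chlorine on the aromatic carbon still gives a 2.2-fold lower number from compound 1 to compound 4 (0.33 log units; beyond the scatter) and so keeps a modest step beyond the scatter without any hydroxymethyl on that chain. Nothing measured on these compounds offers an explanation for any of these steps.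

The compounds shown leave open whether another end group on the same triple-bonded carbon, such as chloromethyl or aminomethyl, would give a number close to that of the bromomethyl compound or to those of the hydroxymethyl and hydrogen compounds. They also leave open whether a longer chain in place of propargyl would change the number at all.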